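A few compounds are considered here, and "the series" means these few. Any claim that something is new, unique, unknown or untested is made for them only; others in the source may bear on it.

The compounds measured so far, with their values:

compound 1 `O=C(NC(=S)Nc1ccccc1)c1ccccc1F` — "not active" (no number reported)
compound 2 `O=C(NC(=S)NCc1cc(C(F)(F)F)cc(C(F)(F)F)c1)c1ccccc1` — 10%
compound 3 `O=C(NC(=S)NCc1ccc(C(F)(F)F)cc1)c1ccccc1` — "not active" (no number reported)

All three were tested in an assay on isolated protein for inhibition of protein deacetylase HDAC6 (Homo sapiens), read by fluorescence, tested at 100 uM; on this read-out higher numbers stand for more inhibition at the one concentration tested (going by the name of the read-out) and lower numbers for less inhibition. Compound 2 is the only one of the three for which a number is reported, and in this assay compound 2 gives 10%. Compound 1 has no single number in this assay; it is reported as "not active" (no number reported). Compound 3 is likewise reported as "not active" (no number reported). Compound 1 therefore stands among the entries without a value, alongside compound 3, and only compound 2 carries a number.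

Compound 4 `O=C(NC(=S)Nc1ccccc1)c1ccccc1` is the compound still to be measured. It differs from compound 1 in one place: hydrogen in place of fluoro on an aromatic carbon. For the measured compounds named here, no step between two measured compounds is known here, so nothing shows how a change of this kind moves the read-out in this assay. Given that compound 1 is reported as "not active" (no number reported), the step to compound 4 is expected to be none beyond the scatter, in either direction.

Compound 4 is expected to give about 5% in this assay, within a range from 0% to 20%.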

Compound 4, a percentage reported as inhibition, at one concentration (the size of the read-out at that concentration, not a potency): 30%
Compound 4: middle estimate off by 25 percentage points, on the low side, outside the stated range (above it).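

In this assay, for the compounds shown here, compound 4 gives 30% and compound 1 is reported as "not active" (no number reported) so no step between compound 1 and compound 4 can be read. No supporting evidence bears on this result. The compounds shown leave open how far hydrogen in place of fluoro moves this read-out.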